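A few compounds are considered here, and "the series" means these few. Any claim that something is new, unique, unknown or untested is made for them only; others in the source may bear on it.

Measured compounds:
compound 1 `O=C(CN1C(=O)/C(=C/c2ccc(-c3ccc(Cl)cc3)o2)SC1=S)NCc1ccc(F)cc1`, in a functional assay on REH cells (Homo sapiens) for cytotoxicity, read by MTT assay, with a stated time of 72 h (on this read-out higher numbers stand for weaker inhibition and lower numbers for stronger inhibition), compound 1 gives 165000 nM
compound 2 `O=C(CN1C(=O)/C(=C/c2ccc(-c3ccc(Cl)cc3)o2)SC1=S)Nc1nnn[nH]1`, in this assay compound 2 gives 50000 nM

Going by the values given here, compound 2 holds the lowest of the two numbers so far; its nearest neighbour is compound 1, and the only step is a 3.3-fold lower number from compound 1 to compound 2 (0.52 log units; beyond the scatter), a modest shift lying beyond the scatter. Compound 3 `CCCNC(=O)CN1C(=O)/C(=C/c2ccc(-c3ccc(Cl)cc3)o2)SC1=S` has not yet been measured in this assay. It differs from compound 2 by propyl in place of 1H-tetrazol-5-yl on an amide-type nitrogen. Among the compounds with values here, the one step that bears on this position is the exchange from compound 1 to compound 2, where a 1H-tetrazol-5-yl group in place of 4-fluorobenzyl lowered the number modestly. Propyl shares with 4-fluorobenzyl the absence of the tetrazole ring and its donor and acceptor count, so a return toward the number of compound 1 is expected, though a propyl group is not a 4-fluorobenzyl group and the series gives no direct reading of it. The step from compound 2 to compound 3 is therefore expected as a 2.4-fold higher number from compound 2 to compound 3 (0.38 log units; beyond the scatter), a modest rise. Compound 3 is estimated at 120000 nM in this assay, with a range from 40000 nM to 350000 nM.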

Compound 3, half-maximal inhibitory concentration: 55000 nM
Beside the measured number, compound 3's estimate is 2.2-fold (0.34 log units) above it; measured number inside the range.
By their numbers in this assay, from the lowest: compounds 2 and 3 (each within the scatter of the next); then compound 1.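

On an amide-type nitrogen, the 1H-tetrazol-5-yl group can give way to propyl, which has no ring and 0 hydrogen-bond donors, with no change beyond the scatter in this assay: a 1.1-fold higher number from compound 2 to compound 3 (0.04 log units; within the scatter). The tetrazole ring is therefore not required for the number seen with compound 2. The step that stands out is instead the one from the 4-fluorobenzyl amide, a 3.0-fold lower number from compound 1 to compound 3 (0.48 log units; beyond the scatter), so compound 1 now sits apart from two quite different groups, and the earlier step no longer reads as a gain specific to the tetrazole. No available evidence accounts for these numbers. As far as these compounds go, whether the 4-fluorobenzyl difference comes from the fluorine or from the benzyl group stays open, as a plain benzyl amide would be needed to separate them. Also open, from the compounds shown here alone, is how a longer chain such as hexyl, or a chain ending in an amine or a carboxylic acid, would read on this nitrogen.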